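Series notes: amide aryl changes on the shared core

The source may report more compounds than this note shows. Statements on the series, on what has been measured and on what is new or still open speak of the compounds shown alone.

Of the compounds shown here, three sharing one core have been measured in a functional assay on A549 cells (Homo sapiens) for inhibition, read by CCK-8 assay, with a stated time of 72 h, tested at 1 uM; on this read-out lower numbers stand for less inhibition of growth and higher numbers for more inhibition of growth at the one concentration tested. Compound 1 `Cc1cccc(NC(=O)C2(C(=O)Nc3ccc(Nc4ncc5cc(C(=O)N(C)C)n(C6CCCC6)c5n4)cc3)CC2)c1` gives 35.2%, the highest of the three numbers. Compound 2 `COC(=O)c1cccc(NC(=O)C2(C(=O)Nc3ccc(Nc4ncc5cc(C(=O)N(C)C)n(C6CCCC6)c5n4)cc3)CC2)c1` gives 10.5% and compound 3 `CN(C)C(=O)c1cc2cnc(Nc3ccc(NC(=O)C4(C(=O)Nc5cccc(Br)c5)CC4)cc3)nc2n1C1CCCC1` gives 20.2%. The step of a number 24.7 percentage points lower from compound 1 to compound 2 (beyond the scatter) and the step of a number 15 percentage points lower from compound 1 to compound 3 (beyond the scatter) both lie beyond the scatter, whereas a number 9.7 percentage points higher from compound 2 to compound 3 (within the scatter) does not; so the two values of compound 2 and compound 3 cannot be ordered.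

Compound 4 `CN(C)C(=O)c1cc2cnc(Nc3ccc(NC(=O)C4(C(=O)Nc5ccc(C#N)cc5)CC4)cc3)nc2n1C1CCCC1` is not yet measured. It differs from compound 1 in one place: 4-cyanophenyl in place of 3-methylphenyl on an amide-type nitrogen. For the measured compounds named here, no measured step exchanges the whole aryl group on the amide nitrogen, so the nearest precedents are the two exchanges of the methyl of compound 1: methoxycarbonyl in compound 2 and bromo in compound 3, each of which lowered the value by a modest amount beyond the scatter. Going by the values given here, the change to compound 4 removes the methyl as well and introduces a nitrile, and on that basis a drop of similar size is expected rather than no change, though its exact size is uncertain because only two precedents exist and neither carries a nitrile.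

Compound 4 is therefore estimated at 18%, within 5% to 32%, which is expected to mean a step of a number 17.2 percentage points lower from compound 1 to compound 4 (beyond the scatter) in this assay.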

Compound 4, percent growth inhibition at one concentration: 86.1%
For compound 4 the middle estimate is 68.1 percentage points below the measured one, outside the stated range (above it).
By their numbers in this assay, from the lowest: compounds 2 and 3 (each within the scatter of the next); then compound 1; then compound 4.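

In this assay the aryl group on the amide-type nitrogen turns out to be able to move the read-out far upward: 4-cyanophenyl gives a number 50.9 percentage points higher from compound 1 to compound 4 (beyond the scatter) and a number 65.9 percentage points higher from compound 3 to compound 4 (beyond the scatter) and also a number 75.6 percentage points higher from compound 2 to compound 4 (beyond the scatter) in the series. The earlier exchanges, methoxycarbonyl and bromo in place of methyl, gave only modest drops from compound 1 and no sign of a rise of this size, so this position is far more sensitive to the choice of aryl group than those compounds suggested. Nothing among the data shown accounts for the size of this rise.

The 4-cyanophenyl of compound 4 differs from the 3-methylphenyl of compound 1 in both the substituent and its place on the ring, and the compounds shown do not separate these two changes. Going by these compounds, it also remains open whether an unsubstituted phenyl, or an amine or a carboxylic acid in place of the nitrile, would hold the value, and how compound 4 would behave at concentrations other than the single one tested.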